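The source may report more compounds than this note shows. Statements on the series, on what has been measured and on what is new or still open speak of the compounds shown alone.

Working notes on the series

Compound 1 `Cc1cc(C)c(S(=O)(=O)NC2=NCCN2C(=S)SN2CCn3c2nsc3=S)c(C)c1` carries a 2,4,6-trimethylphenyl on the sulfonyl sulfur. In a functional assay on KYSE-510 cells (Homo sapiens) for antiproliferative activity, read by crystal violet staining, with a stated time of 96 h (a lower number here means a stronger inhibitor of growth, a higher number a weaker inhibitor of growth), compound 1 gives only a limit of the assay, >= 20000 nM, and no number. Compound 2 `O=S(=O)(NC1=NCCN1C(=S)SN1CCn2c1nsc2=S)c1ccc(Br)cc1` carries a 4-bromophenyl in the same place. In this assay compound 2 likewise gives only a limit, >= 20000 nM, and no number. The step that the two limits leave unreadable from compound 1 to compound 2 is therefore not readable, and both values sit where the limit of >= 20000 nM in this assay, at which 2 of the 2 values shown sit, describes them. Compound 3 `O=S(=O)(NC1=NCCN1C(=S)SN1CCn2c1nsc2=S)c1ccc(Cl)cc1` differs from compound 2 by chloro in place of bromo on an aromatic carbon. Going by the values given here, no measured step reads a change of this kind, and the only two values known both stop at the limit, so nothing suggests that compound 3 should move beyond the scatter in this assay. The step from compound 2 is expected to be a number no higher from compound 2 to compound 3 (the limit leaves the size open). For compound 3 the estimate in this assay is 20000 nM, with a range of 8000 nM to 50000 nM, most likely again reported only as a limit.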

Compound 3, concentration for 50% growth inhibition: >= 20000 nM
Compound 3 was reported as a limit (the forecaster's own chance of this, stated with the estimate: 80%); the middle value sits exactly at the limit.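

Compound 3, like compound 1 and compound 2, gives only a limit in this assay, so no step among the three can be read: the limit of >= 20000 nM in this assay, at which 3 of the 3 values shown sit.

The compounds shown leave open whether any group on the sulfonyl sulfur would give a readable number in this assay.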